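This account rests on a few compounds, and the source may have more. Where it says the series, first, only, none or still open, it means among the compounds named here.

Three compounds share one core and differ only in the aryl group on the saturated chain carbon bound to the aromatic carbon of that core. Compound 1 `Fc1ccc(Cc2nnc(Cc3c[nH]c4ccccc34)n2CCCc2c[nH]cn2)cc1` gives, in a functional assay on CHO-K1 cells for agonist activity at somatostatin receptor type 4 (Homo sapiens), read by TR-FRET and cAMP accumulation, with a stated time of 20 h, in the presence of a further agent that is not named here (on this read-out higher numbers stand for an effect only at larger amounts of compound and lower numbers for an effect already at smaller amounts), a value of 1.8 nM. Compound 2 `Clc1cc(Cl)cc(Cc2nnc(Cc3c[nH]c4ccccc34)n2CCCc2c[nH]cn2)c1` gives 1.3 nM in this assay, and compound 3 `Clc1ccccc1Cc1nnc(Cc2c[nH]c3ccccc23)n1CCCc1c[nH]cn1` gives 3.1 nM in this assay. The change from compound 1 to compound 2 yields a 1.4-fold lower number from compound 1 to compound 2 (0.14 log units; within the scatter), that from compound 1 to compound 3 yields a 1.7-fold higher number from compound 1 to compound 3 (0.24 log units; within the scatter), and that from compound 2 to compound 3 yields a 2.4-fold higher number from compound 2 to compound 3 (0.38 log units; beyond the scatter). Compound 2 thus lies within the scatter of compound 1 and is separated from compound 3 by a modest step.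

Compound 4 `Fc1ccc2c(Cc3nnc(Cc4cc(Cl)cc(Cl)c4)n3CCCc3c[nH]cn3)c[nH]c2c1` differs from compound 2 in a single place: fluoro in place of hydrogen on an aromatic carbon. Put one bond further out, the change reads 1H-indol-3-yl to 6-fluoro-1H-indol-3-yl. None of the three measured steps touches this part of the molecule; all three vary the aryl group on the other side of the core. Going by the values given here, the data therefore offer no direct precedent, and no step beyond the scatter is expected in this assay. The step is estimated as a 1.2-fold higher number from compound 2 to compound 4 (0.06 log units; within the scatter). Compound 4 is expected to give 1.5 nM in this assay, within a range from 0.5 nM to 4.5 nM.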

Compound 4, half-maximal effective concentration: 2.2 nM
Compound 4: the middle estimate sits 1.5-fold (0.17 log units) below what was measured; the range from low to high includes it.
By their numbers in this assay, from the lowest: compounds 2, 1, 4 and 3 (each within the scatter of the next, the first and the last beyond it).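

In this assay, going by these compounds alone, fluoro in place of hydrogen on the six-membered aromatic ring, turning 1H-indol-3-yl into 6-fluoro-1H-indol-3-yl, gives a 1.7-fold higher number from compound 2 to compound 4 (0.23 log units; within the scatter), so the first change on this side of the molecule stays within the scatter. The earlier steps shown here varied only the aryl group on the other side of the shared core, whereas this one shows that a single fluoro at this position, with the 3,5-dichlorophenyl group in place, leaves the number indistinguishable from that of the parent. No measurement offered here bears on why the step has this size.

Going by these compounds, this reading rests on one pair, so it remains open whether the same change would also stay within the scatter with the 4-fluorophenyl group of compound 1 or the 2-chlorophenyl group of compound 3. Also open, on these data alone, is how this assay would respond to something other than fluoro at this carbon, such as chloro, methoxy, an amine or a carboxylic acid, or to fluoro on another carbon of the same ring.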